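Replacing a ring by an open chain on a shared core

The compounds below may be only part of what the source reports. "The series", "measured", "known", "first", "only" and "open" are said of these compounds alone.

In a functional assay for activation of Alpha-1B adrenergic receptor (Homo sapiens), read by calcium flux (a higher number here means that more compound is needed for the effect, a lower number that less compound is needed), compound 1, `c1coc(-c2ccccc2NCC2=NCCN2)c1`, gives 6.31 nM. Compound 3, `Cc1nc(-c2ccccc2NCC2=NCCN2)no1`, gives 676 nM in this assay. Compound 2, `Cc1nc(-c2ccccc2NCC2=NCCN2)co1`, reaches only a limit of the assay, < 5020 nM, so its number is not known; this is the limit described as the limit of < 5020 nM in this assay, at which 1 of the 3 values shown sits. Among the two numbers actually read, compound 3 stands highest, and the only readable step to it is a 110-fold higher number from compound 1 to compound 3 (2.03 log units; beyond the scatter). The steps a step that the limit leaves unreadable from compound 1 to compound 2 and a step that the limit leaves unreadable from compound 2 to compound 3 cannot be sized.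

Compound 4, `CCO/N=C(\C)c1ccccc1NCC1=NCCN1`, has not been measured. It differs from compound 3 by a group of 6 heavy atoms (4 carbon, 1 nitrogen, 1 oxygen; no ring) in place of a group of 6 heavy atoms (3 carbon, 2 nitrogen, 1 oxygen; one five-membered aromatic ring with 3 hetero atoms), on an aromatic carbon. Among the compounds with values here, no measured step swaps a five-membered aromatic ring for an open chain; the only readable step, a 110-fold higher number from compound 1 to compound 3 (2.03 log units; beyond the scatter), shows that exchanging one five-membered aromatic ring for another can move the number a great deal in this assay. The expectation for compound 4 therefore carries wide uncertainty. Since compound 3 sits far from compound 1, the estimate for compound 4 is placed between them, and the step of a 3.4-fold lower number from compound 3 to compound 4 (0.53 log units; beyond the scatter) is expected in the direction of a lower number. Compound 4 is estimated at 200 nM, with a range from 20 nM to 2000 nM.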

Compound 4, half-maximal effective concentration: < 5020 nM
Compound 4: no number, only a limit (the forecaster's own chance of this, stated with the estimate: 10%); the middle value does not contradict the limit.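

In this assay compound 4 reaches only a limit of the assay, < 5020 nM, so none of its steps to compound 1, compound 2 or compound 3 can be read. The compounds shown leave open how much replacing the five-membered aromatic ring of compound 3 with the open chain of compound 4 actually changes the number.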